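Alkyl growth on one aromatic carbon: methyl to tert-butyl

The source may report more compounds than this note shows. Statements on the series, on what has been measured and on what is new or still open speak of the compounds shown alone.

Measured compounds:
compound 1, `Cc1ccccc1NC(=O)N[C@H](C)c1ccccc1`: 100%
compound 2, `CC(C)c1ccccc1NC(=O)N[C@H](C)c1ccccc1`: 101%

In an ADME assay on the whole organism with Oryza sativa as the target, tested at 1 uM (on this read-out lower numbers stand for a stronger effect and higher numbers for a weaker effect at the one concentration tested), compound 1 gives 100% and compound 2 gives 101%. Among the compounds with values here, the only measured step, a number 1 percentage points higher from compound 1 to compound 2 (within the scatter), is isopropyl in place of methyl on an aromatic carbon; the two numbers lie within the scatter of each other, so compound 2 stands level with compound 1 and no order between them can be read.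

Compound 3, `C[C@@H](NC(=O)Nc1ccccc1C(C)(C)C)c1ccccc1`, carries the same difference cut one bond further out, isopropyl to tert-butyl; counted against compound 2 it is methyl in place of hydrogen on a saturated chain carbon bound to an aromatic carbon and two saturated chain carbons. Within the data shown here, the one step that bears on it, a number 1 percentage points higher from compound 1 to compound 2 (within the scatter), stayed within the scatter. The step from compound 2 is therefore expected to be a number 1 percentage points lower from compound 2 to compound 3 (within the scatter), none beyond the scatter. For compound 3 the estimate is 100%, with a range from 90% to 110%.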

Compound 3, a percentage reported as activity, at one concentration (the size of the read-out at that concentration, not a potency): 95%
The estimate for compound 3 lay 5 percentage points above the measured number, and the stated range covers the measured number.
By their numbers in this assay, from the lowest: compounds 3, 1 and 2 (each within the scatter of the next).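

In this assay, methyl in place of hydrogen on a saturated chain carbon bound to an aromatic carbon and two saturated chain carbons gives a number 6 percentage points lower from compound 2 to compound 3 (within the scatter), and the whole move from methyl to tert-butyl on the aromatic carbon gives a number 5 percentage points lower from compound 1 to compound 3 (within the scatter). Compound 1, compound 2 and compound 3 therefore stand level, and even tert-butyl, the largest of the three alkyl groups, does not separate from methyl or isopropyl at this position. No supporting evidence bears on this result, and it offers no explanation for it.

Whether any group on this aromatic carbon can move the read-out beyond the scatter remains open, as alkyl groups alone are shown here. A methoxy group, an amine or a carboxylic acid at this position would put that question to the test.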